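Methoxy in place of phenylsulfanyl on the shared core

A few compounds are considered here, and "the series" means these few. Any claim that something is new, unique, unknown or untested is made for them only; others in the source may bear on it.

In a functional assay on the whole organism with Mus musculus as the target (a lower number here means that less compound is needed, a higher number that more compound is needed for the effect), compound 3 `Cc1c(C)c2c(c(C)c1N)CC(C)(CSc1ccccc1)O2` stands at 24.7 mg/kg and within the scatter of compound 2 `CC(C)=Cc1c(C)c(N)c(C)c2c1OC(C)(C)C2` at 21.9 mg/kg in the same read-out. Compound 1 `Cc1c(C)c2c(c([N+](=O)[O-])c1N)CC(C)(C)O2` gives > 100 mg/kg as a limit of the assay and not a number. Compound 4 `COCC1(C)Cc2c(C)c(N)c(C)c(C)c2O1`, still unmeasured, carries methoxy in place of phenylsulfanyl on a saturated chain carbon bound to a saturated ring carbon, a change counted as methoxy in place of phenylsulfanyl on a saturated chain carbon bound to a saturated ring carbon in full. Going by the values given here, no measured step bears on this change, so the expectation rests on compound 3 at 24.7 mg/kg as its starting value. In this assay no change beyond the scatter is expected, with an estimated step of a 1.2-fold higher number from compound 3 to compound 4 (0.08 log units; within the scatter) toward a higher number. Compound 4 is expected at 30 mg/kg with an estimated range of 11 mg/kg to 85 mg/kg in this read-out.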

Compound 4, dose for 50% inhibition: 20.1 mg/kg
Compound 4: middle estimate off by 1.5-fold (0.17 log units), on the high side; low and high end bracket the measured number.
By their numbers in this assay, from the lowest: compounds 4, 2 and 3 (each within the scatter of the next). At a limit, above all of these: compound 1.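

In this assay the step of a 1.2-fold lower number from compound 3 to compound 4 (0.09 log units; within the scatter) shows that methoxy can take the place of phenylsulfanyl on a saturated chain carbon bound to a saturated ring carbon with no change beyond the scatter. This position therefore keeps its number without the aromatic ring and without the sulfur. Nothing at hand gives a cause for this step. Going by these compounds, whether an amine, a carboxylic acid or a longer chain at this place would keep the number in the same range stays open.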